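The compounds below may be only part of what the source reports. "The series", "measured", "known", "first", "only" and "open" are said of these compounds alone.

Compound 1 `S=c1oc(-c2ccc3c(c2)OCCO3)nn1CN1CCN(c2ccccc2)CC1`: > 50000 nM
Compound 2 `COc1ccccc1N1CCN(Cn2nc(-c3ccc4c(c3)OCCO4)oc2=S)CC1`: > 50000 nM
Compound 3 `COc1cccc(N2CCN(Cn3nc(-c4ccc5c(c4)OCCO5)oc3=S)CC2)c1`: 18000 nM

Among the measured compounds shown here, in a functional assay on HeLa cells (Homo sapiens) for antiproliferative activity, read by MTT assay, with a stated time of 48 h (a lower number here means a stronger inhibitor, a higher number a weaker inhibitor), compound 3 gives 18000 nM, the only number among the three compounds. Compound 1 shows only the limit > 50000 nM. Compound 2 likewise shows only the limit > 50000 nM. For the measured compounds named here, the two steps that lead to compound 3, an at least 2.7-fold lower number from compound 1 to compound 3 (0.44 log units; beyond the scatter) and an at least 2.7-fold lower number from compound 2 to compound 3 (0.44 log units; beyond the scatter), are the only steps that can be read, and both set compound 3 apart from the limit of > 50000 nM in this assay, at which 2 of the 3 values shown sit; the step that the two limits leave unreadable from compound 1 to compound 2 cannot be sized.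

Compound 4 `S=c1oc(-c2ccc3c(c2)OCCO3)nn1CN1CCN(c2ccccn2)CC1` differs from compound 3 in one place: pyridin-2-yl in place of 3-methoxyphenyl on an amine nitrogen in a ring. Going by the values given here, no measured step exchanges a phenyl for a pyridinyl group, so the two readable steps bear on it only indirectly, in that they show the 3-methoxyphenyl of compound 3 to be what carries its number below the limit. Removing that group is therefore expected to move compound 4 back toward the limit. Compound 4 is estimated at 40000 nM, with a range from 15000 nM to 100000 nM. This estimate means a step of a 2.2-fold higher number from compound 3 to compound 4 (0.35 log units; beyond the scatter).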

Compound 4, half-maximal inhibitory concentration: 25100 nM
Compound 4: middle estimate off by 1.6-fold (0.20 log units), on the high side; low and high end bracket the measured number.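

Among the compounds shown here, the exchange of 3-methoxyphenyl for pyridin-2-yl on the amine nitrogen in the ring gives a 1.4-fold higher number from compound 3 to compound 4 (0.14 log units; within the scatter), so in this assay the 3-methoxyphenyl group is not the only group at this position that yields a number rather than a limit. Set against the other two groups, pyridin-2-yl gives an at least 1.9-fold lower number from compound 1 to compound 4 (0.29 log units; that floor lies within the scatter) and an at least 1.9-fold lower number from compound 2 to compound 4 (0.29 log units; that floor lies within the scatter), and since both floors lie within the scatter, neither step alone firmly separates it from phenyl or 2-methoxyphenyl. The step between compound 1 and compound 2 still cannot be read, as both values are limits: the limit of > 50000 nM in this assay, at which 2 of the 4 values shown sit.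

The compounds shown leave open whether a benzyl or an acetyl group on this nitrogen would give a lower number in this assay. They also leave open whether any group here can move the number far from the values seen so far.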